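Bromo replaces methylsulfanyl

A few compounds are considered here, and "the series" means these few. Any claim that something is new, unique, unknown or untested is made for them only; others in the source may bear on it.

In a functional assay on the whole organism (Pleural cavity) for inhibition, with Rattus norvegicus as the target, at a dose of 25 mg/kg (a higher number here means more inhibition at the dose given (going by the name of the read-out), a lower number less inhibition), compound 1 `COc1ccc(N2C(=O)C(C)(C)c3cccnc32)cc1` gives 63%, compound 3 `CSc1ccc(N2C(=O)C(C)(C)c3cccnc32)cc1` gives 29% and compound 2 `CC1(Cc2ccccc2)C(=O)N(c2ccccc2)c2ncccc21` gives 9%. Compound 3 thus stands second of the three, below compound 1 and above compound 2, both gaps beyond the scatter. Among the measured compounds shown here, the one measured step at this position, a number 34 percentage points lower from compound 1 to compound 3 (beyond the scatter), is large. Compound 4 `CC1(C)C(=O)N(c2ccc(Br)cc2)c2ncccc21` is the next member; the change is bromo in place of methylsulfanyl on an aromatic carbon, set on an aromatic carbon of a six-membered aromatic ring of carbon only, para to a large group. For the measured compounds named here, no measured step exchanges methylsulfanyl for bromo, so the earlier step gives only the scale of what a swap here can do, not its direction. The expected step is a number 1 percentage points higher from compound 3 to compound 4 (within the scatter), within the scatter. The estimate for compound 4 is 30%, within 10% to 55%.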

Compound 4, a percentage reported as inhibition, in the whole organism at one dose (the size of the read-out at that dose, not a potency): 46%
The estimate for compound 4 lay 16 percentage points below the measured number; measured number inside the range.
By their numbers in this assay, from the lowest: compound 2; then compound 3; then compound 4; then compound 1.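

At this position, on an aromatic carbon para to a large group, the swap of methylsulfanyl for bromo moves the read-out in this assay upward (a number 17 percentage points higher from compound 3 to compound 4 (beyond the scatter)). Bromo does not match methoxy (a number 17 percentage points lower from compound 1 to compound 4 (beyond the scatter)), so the three groups now form an order beyond the scatter, with methoxy highest, bromo in the middle and methylsulfanyl lowest. Heavy-atom count does not track this order, since bromo, the smallest group here, sits in the middle. From the compounds shown here alone, whether an amine, a hydroxyl or a longer chain such as ethoxy would reach methoxy here stays open. Nothing available on these compounds accounts for the order of the three groups.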